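The source may hold more compounds than are shown below. What is called first, only, known or untested is meant among the compounds shown, and "the series" means these compounds.

Measured compounds in this series:
compound 1 `COc1ccc2c(c1)[C@@H](O)CN(C)C2`, a limit of the assay: > 100000 nM
compound 2 `Cc1cccc(COc2ccc3c(c2)[C@@H](O)CN(C)C3)c1`, a limit of the assay: > 50000 nM
compound 3 `Cc1ccccc1COc1ccc2c(c1)[C@@H](O)CN(C)C2`, a limit of the assay: > 100000 nM

All three values come from an ADME assay on Vero cells (Chlorocebus sabaeus) for cytotoxicity, read by sulforhodamine B assay, with a stated time of 72 h (on this read-out higher numbers stand for weaker inhibition and lower numbers for stronger inhibition), and none is a number. In this assay compound 1 gives > 100000 nM, a limit. Compound 2 gives > 50000 nM, also a limit. Compound 3 gives > 100000 nM, again a limit. Compound 3 therefore stands at the limit of > 100000 nM in this assay, at which 2 of the 3 values shown sit, while compound 2 sits at the limit of > 50000 nM in this assay, at which 1 of the 3 values shown sits. The steps between the measured compounds are a step that the two limits leave unreadable from compound 1 to compound 2, a step that the two limits leave unreadable from compound 1 to compound 3 and a step that the two limits leave unreadable from compound 2 to compound 3, so no size can be read from any of them.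

Compound 4 `CN1Cc2ccc(OCC3CCCCC3)cc2[C@@H](O)C1` differs from compound 3 by cyclohexyl in place of 2-methylphenyl on a saturated chain carbon bound to an oxygen on an aromatic ring. Among the compounds with values here, the measured steps bear on this change only in that every exchange at the same place so far has left the value at a limit; none gives a readable size or direction. No step beyond the scatter is therefore expected in this assay.

Compound 4 is estimated at 100000 nM, with a range from 50000 nM to 200000 nM, most likely reported as a limit once more. The step of a number no higher from compound 3 to compound 4 (the limit leaves the size open) implied by this estimate is expected to be none beyond the scatter.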

Compound 4, half-maximal inhibitory concentration: 65600 nM
For compound 4 the middle estimate is 1.5-fold (0.18 log units) above the measured one; low and high end bracket the measured number.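

In this assay compound 4 gives 65600 nM, a number rather than a limit and the first at this place on a saturated chain carbon bound to an oxygen on an aromatic ring. Against the limits of the two compounds that allow a reading, cyclohexyl in place of 2-methylphenyl gives an at least 1.5-fold lower number from compound 3 to compound 4 (0.18 log units; that floor lies within the scatter), and cyclohexyl in place of hydrogen gives an at least 1.5-fold lower number from compound 1 to compound 4 (0.18 log units; that floor lies within the scatter), so neither floor establishes a change beyond the scatter, although the exchange of an aromatic ring for a non-aromatic one has now produced a readable value. The step from compound 2 to compound 4 cannot be read, and compound 3 stays a limit: the limit of > 100000 nM in this assay, at which 2 of the 4 values shown sit.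

From the compounds shown here alone, the true size of the steps to compound 4 remains open, as does whether the readable value is particular to cyclohexyl or would also appear with a smaller saturated ring such as cyclopentyl. Also open, going by these compounds, is whether a longer chain between the oxygen and the ring, or an amine or a carboxylic acid on that ring, would move the number in this assay beyond the scatter.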